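Fluoro to methoxy on a bis-arylidene cyclohexanone scaffold

The source may report more compounds than this note shows. Statements on the series, on what has been measured and on what is new or still open speak of the compounds shown alone.

Compound 1 `O=C1/C(=C/c2ccc(F)cc2)CCC/C1=C\c1cccc([N+](=O)[O-])c1` and compound 2 `O=C1/C(=C/c2ccccc2)CCC/C1=C\c1ccccc1[N+](=O)[O-]` share a cyclic ketone core carrying two arylidene arms, one of them bearing a nitro group. In a functional assay on CCRF-CEM cells (Homo sapiens) for cytotoxicity, with a stated time of 72 h (on this read-out higher numbers stand for weaker inhibition and lower numbers for stronger inhibition), compound 1 gives 5050 nM, the highest of the two numbers at hand, while compound 2 gives 925 nM in this assay, a lower number that lies beyond the scatter; since the two compounds differ in more than one place, no single step can be read from that pair. Compound 3 `COc1ccc(/C=C2\CCC/C(=C\c3cccc([N+](=O)[O-])c3)C2=O)cc1` has not yet been measured. It differs from compound 1 by methoxy in place of fluoro on an aromatic carbon. Among the measured compounds shown here, with no measured step of this kind available, only a small shift is expected from compound 1 to compound 3 in this assay, a 1.3-fold lower number from compound 1 to compound 3 (0.10 log units; within the scatter), not clearly beyond the scatter in either direction. Compound 3 is therefore estimated at 4000 nM in this assay, within a range of 1500 nM to 12000 nM.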

Compound 3, half-maximal inhibitory concentration: 8220 nM
Estimate against measurement, compound 3: 2.1-fold (0.31 log units) below; measured number inside the range.
By their numbers in this assay, from the lowest: compound 2; then compounds 1 and 3 (each within the scatter of the next).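

In this assay, among the compounds shown here, the first single-place step at this position, methoxy in place of fluoro on an aromatic carbon para to a large group, gives a 1.6-fold higher number from compound 1 to compound 3 (0.21 log units; within the scatter). The 4-fluorophenyl and 4-methoxyphenyl arms therefore cannot be told apart on this read-out, even though the change adds a heavy atom and a hydrogen-bond acceptor. No supporting measurement speaks to the reason for this result.

From the compounds shown here alone, whether an amine or a carboxylic acid on this aromatic carbon would move the number beyond the scatter remains open. Also open, going by these compounds, is which of the several differences between compound 1 and compound 2 goes with the lower number of compound 2, 925 nM, and whether the step seen here would hold with the nitro-bearing arm changed.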